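The source may report more compounds than this note shows. Statements on the series, on what has been measured and on what is new or still open speak of the compounds shown alone.

In a functional assay on MDA-MB-436 cells (Homo sapiens) for antiproliferative activity, read by MTT assay, with a stated time of 48 h (a higher number here means a weaker inhibitor, a lower number a stronger inhibitor), compound 1 (`C=CS(=O)(=O)N1CCN(c2ncnc3sc(-c4ccc(N5CCN(C)CC5)cc4)cc23)CC1`) gives 8760 nM while compound 2 (`C=CS(=O)(=O)N1CCN(c2nc(OC[C@H]3CCCN3C)nc3sc(-c4ccc(N5CCN(C)CC5)cc4)cc23)[C@@H](C)C1`) gives 1920 nM as the lower of the two numbers, a gap beyond the scatter. Compound 3 (`C=CS(=O)(=O)N1CCN(c2ncnc3sc(-c4ccc(N5CCN(C)CC5)cc4)cc23)[C@@H](C)C1`) differs from compound 2 by a single change (hydrogen in place of (1-methylpyrrolidin-2-yl)methoxy on an aromatic carbon), hydrogen in place of (1-methylpyrrolidin-2-yl)methoxy on an aromatic carbon. Among the compounds with values here, no measured pair isolates this change, so its size can only be judged indirectly. Compound 1 also carries hydrogen at that place and stands at 8760 nM in the same test, although it lacks the methyl of the 2-methyl-4-(vinylsulfonyl)piperazin-1-yl group found in compound 3. A move towards a higher number, weaker inhibition, is therefore expected, probably beyond the scatter. The expected size is a 3.1-fold higher number from compound 2 to compound 3 (0.49 log units; beyond the scatter) for this change. Compound 3 is estimated at 6000 nM (range 2800 nM to 13000 nM).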

Compound 3, half-maximal inhibitory concentration: 6920 nM
The estimate for compound 3 lay 1.2-fold (0.06 log units) below the measured number; measured number inside the range.
By their numbers in this assay, from the lowest: compound 2; then compounds 3 and 1 (each within the scatter of the next).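

In this assay, the loss of the (1-methylpyrrolidin-2-yl)methoxy group from the aromatic carbon between two ring nitrogen atoms now has a directly measured size: a 3.6-fold higher number from compound 2 to compound 3 (0.56 log units; beyond the scatter). The second pair isolates the methyl on the saturated ring carbon, and this change gives a 1.3-fold lower number from compound 1 to compound 3 (0.10 log units; within the scatter), so in this pair the methyl makes no difference beyond the scatter. Nothing available explains either step.

Only hydrogen and this one group are shown at that aromatic carbon, so it remains open whether the effect depends on the pyrrolidine ring, its tertiary amine or the ether oxygen. A plain methoxy group, an open-chain dimethylaminoethoxy group or the opposite configuration of the pyrrolidine stereocentre would help to separate these parts.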